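Neopentyl for isobutyl on the dipeptide-type core

The source may report more compounds than this note shows. Statements on the series, on what has been measured and on what is new or still open speak of the compounds shown alone.

Three compounds of the shared core have numbers in an in vitro ADME assay on microsomes from liver (Homo sapiens) for metabolic stability; a lower number here means slower removal, a higher number faster removal of the compound. Compound 1 `CC[C@H](C)[C@@H]1C(=O)N[C@H](C2Cc3ccccc3C2)C(=O)N1[C@@H](C(=O)N(C)C)c1ccc(C)[n+]([O-])c1` gives 1 mL.min-1.g-1 in this assay. Compound 3 `CCC(CC)[C@@H]1C(=O)N[C@H](C2Cc3ccccc3C2)C(=O)N1[C@@H](C(=O)N1CCOCC1)c1ccc(C)nc1` gives 12 mL.min-1.g-1 in this assay. Compound 2 `Cc1ccc([C@H](C(=O)N(C)C)N2C(=O)[C@@H](C3Cc4ccccc4C3)NC(=O)[C@H]2CC(C)C)cn1` gives 11000 mL.min-1.g-1 in this assay, the highest of the three numbers, beyond the scatter from compound 3 and further still from compound 1. No two of the measured compounds differ in one place only, so the separate contributions of the side chain, the amide and the pyridine oxidation state cannot be taken apart from these numbers.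

Compound 4 `Cc1ccc([C@H](C(=O)N(C)C)N2C(=O)[C@@H](C3Cc4ccccc4C3)NC(=O)[C@H]2CC(C)(C)C)cn1` is the next compound, differing from compound 2 by methyl in place of hydrogen on a saturated chain carbon bound to three saturated chain carbons. Among the compounds with values here, with no single-change step between measured compounds to lean on, the expected step from compound 2 to compound 4 in this assay is small, a modest lowering at most, a 1.8-fold lower number from compound 2 to compound 4 (0.26 log units; within the scatter), and may lie within the scatter. Compound 4 is therefore estimated at 6000 mL.min-1.g-1, in the range 1500 mL.min-1.g-1 to 20000 mL.min-1.g-1.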

Compound 4, intrinsic clearance in microsomes: 6 mL.min-1.g-1
Beside the measured number, compound 4's estimate is 1000-fold (3.00 log units) above it, and the stated range ends above it.
By their numbers in this assay, from the lowest: compound 1; then compounds 4 and 3 (each within the scatter of the next); then compound 2.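

In this assay, within the data shown here, isobutyl to neopentyl gives a 1800-fold lower number from compound 2 to compound 4 (3.26 log units; beyond the scatter) and is the first single-change step. The amide and the pyridine oxidation state stay the same across this pair, so a change at this side chain alone, by one methyl in place of hydrogen on a saturated chain carbon bound to three saturated chain carbons, is enough to give a step beyond the scatter. No measurement at hand accounts for the size of this step.

As far as these compounds go, whether cyclopropylmethyl or a longer chain at this position would fall near compound 4 or near compound 2 remains open. From the compounds shown here alone, it is also open whether the isobutyl to neopentyl step keeps its size with a different amide or pyridine oxidation state.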